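The compounds below may be only part of what the source reports. "The series", "measured", "known", "first", "only" and "open" are said of these compounds alone.

Measured compounds:
compound 1, `COc1ccc2c(c1)C(=O)C(=O)N2CCCn1cc(COc2cc(=O)oc3ccccc23)nn1` — 48%
compound 2, `COc1ccc2c(c1)C(=O)C(=O)N2CCCCn1cc(COc2cc(=O)oc3ccccc23)nn1` — 41%
compound 3, `O=C1C(=O)N(CCCCn2cc(COc3cc(=O)oc4ccccc34)nn2)c2ccc(Br)cc21` — 56%

All three numbers come from a functional assay on COLO 205 cells (Homo sapiens) for inhibition, read by sulforhodamine B assay, with a stated time of 48 h, tested at 50 uM; a higher number here means more inhibition of growth at the concentration tested, a lower number less inhibition of growth. Compound 1 stands second highest of the three, but its gaps to compound 2 and to compound 3 both lie within the scatter, so no order among the three can be claimed. Among the compounds with values here, the one step that exceeds the scatter is a number 15 percentage points higher from compound 2 to compound 3 (beyond the scatter), in which bromo replaces methoxy on an aromatic carbon of the shared core.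

Compound 4, `O=C1C(=O)N(CCCn2cc(COc3cc(=O)oc4ccccc34)nn2)c2ccc([N+](=O)[O-])cc21`, has not yet been tested in this assay. It differs from compound 1 as follows: nitro in place of methoxy on an aromatic carbon. Within the data shown here, the change sits on the same aromatic carbon as the one in the step from compound 2 to compound 3, and again removes methoxy, though nitro rather than bromo enters. That step is the only one bearing on the present change, and it was modest. On this single precedent a modest rise in this assay is expected for compound 4, of about the size seen in a number 15 percentage points higher from compound 2 to compound 3 (beyond the scatter); it is estimated as a number 10 percentage points higher from compound 1 to compound 4 (within the scatter). Compound 4 is therefore expected to give about 58%, with a range from 40% to 76%.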

Compound 4, percent growth inhibition at one concentration: 52%
Beside the measured number, compound 4's estimate is 6 percentage points above it; the measured number falls inside the stated range.
By their numbers in this assay, from the lowest: compounds 2, 1, 4 and 3 (each within the scatter of the next, the first and the last beyond it).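

In this assay the replacement of methoxy by nitro on this aromatic carbon gives a number 4 percentage points higher from compound 1 to compound 4 (within the scatter) and so, unlike the replacement by bromo, which gave a number 15 percentage points higher from compound 2 to compound 3 (beyond the scatter) on the other chain, cannot be told apart from repeat scatter. The earlier compounds shown here showed a single replacement of methoxy at this carbon that exceeded the scatter, whereas compound 4 shows that losing methoxy here does not by itself carry a step of that kind. The two replacements also stand on different chains, so neither step can be set against the other as a clean measure of the entering group alone.

From the compounds shown here alone, whether bromo and nitro would read alike on one and the same chain stays open, as compound 3 and compound 4 differ in two places and are not compared here. Also open, going by these compounds, is how an amine, a carboxylic acid or a plain hydrogen on this carbon would read, and whether a longer chain would shift any of these numbers. No measurement at hand speaks to what lies behind these results.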